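Removing One Fluorine from Compound 1

A few compounds are considered here, and "the series" means these few. Any claim that something is new, unique, unknown or untested is made for them only; others in the source may bear on it.

Measured compounds:
compound 1, `CCC(CC)(c1nnc[nH]1)c1ccc(-c2ccc3cc(F)cc(F)c3c2)[nH]c1=O`, 350 nM
compound 2, `CCn1ncc2c(F)cc(-c3ccc(C(CC)(CC)c4nnc(C)[nH]4)c(=O)[nH]3)cc21`, 90 nM
compound 3, `CCn1ncc2c(F)cc(-c3ccc(C(CC)(CC)c4nncn4C)c(=O)[nH]3)cc21`, 120 nM

These three were tested in a functional assay on CHO cells for antagonist activity at prostaglandin E2 receptor EP3 subtype (Homo sapiens), read by cAMP accumulation; on this read-out lower numbers stand for stronger inhibition and higher numbers for weaker inhibition. Compound 1 gives the highest number of the three in this assay; compound 3 sits nearer to it, and compound 2 furthest from it, both beyond the scatter. Compound 4, `CCC(CC)(c1nnc[nH]1)c1ccc(-c2ccc3cccc(F)c3c2)[nH]c1=O`, is not yet measured. It differs from compound 1 by hydrogen in place of fluoro on an aromatic carbon.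

Going by the values given here, no measured pair shows this kind of change. Among the compounds with values here, the only single-point step at hand, a 1.3-fold higher number from compound 2 to compound 3 (0.12 log units; within the scatter), concerns the methyl position on the triazole and has no bearing on removing a fluoro. With nothing to lean on, a step in this assay for compound 4 of no more than the scatter is expected, with the direction open. The estimate for compound 4 is 450 nM, in a range from 150 nM to 1400 nM, which is expected to mean a 1.3-fold higher number from compound 1 to compound 4 (0.11 log units; within the scatter).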

Compound 4, half-maximal inhibitory concentration: 36 nM
For compound 4 the middle estimate is 13-fold (1.10 log units) above the measured one; measured number outside the range, below it.
By their numbers in this assay, from the lowest: compound 4; then compounds 2 and 3 (each within the scatter of the next); then compound 1.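

Replacing one fluoro with hydrogen gives a 9.7-fold lower number from compound 1 to compound 4 (0.99 log units; beyond the scatter) in this assay and so moves the number well beyond the scatter. Going by these compounds alone, this shows that the aromatic carbon meta to the remaining fluoro group is sensitive to a change of a single heavy atom, which the earlier compounds could not show, as their only single-point step concerned the methyl position on the triazole. No measurement at hand explains this step.

The compounds shown leave open how other groups on this carbon, such as chloro, methyl, methoxy or an amine, would compare with hydrogen and fluoro. As far as these compounds go, it also remains open whether replacing the fluoro that stays in compound 4 with hydrogen would move the number in the same direction or by a similar amount.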